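Swapping a chloroaryl for a benzyl on the amidine nitrogen

The source may hold more compounds than are shown below. What is called first, only, known or untested is meant among the compounds shown, and "the series" means these compounds.

Measured so far:
compound 1 `Cc1ccc(S(=O)(=O)/N=C(/CCNC2=CC(=O)c3ccccc3C2=O)Nc2ccc(Cl)cc2)cc1` — 13400 nM
compound 2 `Cc1ccc(S(=O)(=O)/N=C(/CCNC2=CC(=O)c3ccccc3C2=O)Nc2ccc(Cl)cc2Cl)cc1` — 20500 nM

Of the compounds shown here, two sharing one core have been tested in a functional assay on HeLa cells (Homo sapiens) for cytotoxicity, read by MTT assay, with a stated time of 48 h; a lower number here means a stronger inhibitor, a higher number a weaker inhibitor. Compound 1 `Cc1ccc(S(=O)(=O)/N=C(/CCNC2=CC(=O)c3ccccc3C2=O)Nc2ccc(Cl)cc2)cc1` gives 13400 nM. Compound 2 `Cc1ccc(S(=O)(=O)/N=C(/CCNC2=CC(=O)c3ccccc3C2=O)Nc2ccc(Cl)cc2Cl)cc1`, which carries a chloro in place of hydrogen on an aromatic carbon, gives 20500 nM. Compound 1 thus stands with one neighbour only, and the step of a 1.5-fold higher number from compound 1 to compound 2 (0.18 log units; within the scatter) shows the two cannot be told apart beyond the scatter.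

Compound 3 `Cc1ccc(S(=O)(=O)/N=C(/CCNC2=CC(=O)c3ccccc3C2=O)NCc2ccccc2)cc1` has not yet been measured. It differs from compound 1 by benzyl in place of 4-chlorophenyl on an amine nitrogen. Within the data shown here, no measured step changes this same part of the molecule in this way; the only step available, a 1.5-fold higher number from compound 1 to compound 2 (0.18 log units; within the scatter), alters the same ring by a single chloro and leaves the number essentially unchanged. That offers no ground for expecting a large move in either direction.

The expected step from compound 1 to compound 3 is therefore a 1.1-fold higher number from compound 1 to compound 3 (0.05 log units; within the scatter), within the scatter. Compound 3 is estimated at 15000 nM, with a range from 5000 nM to 45000 nM.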

Compound 3, half-maximal inhibitory concentration: 3980 nM
Compound 3: the middle estimate sits 3.8-fold (0.58 log units) above what was measured; measured number below the stated range.
By their numbers in this assay, from the lowest: compound 3; then compounds 1 and 2 (each within the scatter of the next).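

In this assay the group on this amine nitrogen proves able to move the number: benzyl in place of 4-chlorophenyl gives a 3.4-fold lower number from compound 1 to compound 3 (0.53 log units; beyond the scatter) and benzyl in place of 2,4-dichlorophenyl gives a 5.2-fold lower number from compound 2 to compound 3 (0.71 log units; beyond the scatter) with the same direction of change. Both steps are modest, yet they lie beyond the scatter, whereas the earlier step of a 1.5-fold higher number from compound 1 to compound 2 (0.18 log units; within the scatter) did not separate the two compounds it joins, so altering the chlorine count on the ring told little, while replacing the whole group does register. Nothing available explains why this replacement gives a lower number.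

The replacement removes the chlorine and turns the aryl group into a benzyl group at once, so the compounds shown cannot say which of these two differences goes with the lower number. A plain phenyl or a 4-chlorobenzyl group on this nitrogen would pull the two apart, and a 2-phenylethyl group, with its longer chain, would show whether the trend continues.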